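The source may hold more compounds than are shown below. What is called first, only, known or untested is meant among the compounds shown, and "the series" means these compounds.

Measured so far in an assay on isolated protein for inhibition of leukotriene B4 receptor 1 (Homo sapiens), tested at 10 uM; a lower number here means less inhibition, a higher number more inhibition at the concentration tested (going by the name of the read-out):
compound 1 `CCc1cc(C(C)=O)c(O)cc1OCCCCC#N` — 92%
compound 2 `CCCCCCc1cc(C(C)=O)c(O)cc1OCCCCC#N` — 51%

Going by the values given here, compound 2 stands lowest of the two numbers in this assay; the only measured step is a number 41 percentage points lower from compound 1 to compound 2 (beyond the scatter), which puts butyl in place of hydrogen on the chain. Compound 3 `CC(=O)c1cc(CC(C)O)c(OCCCCC#N)cc1O` differs from compound 2 by 1-hydroxyethyl in place of pentyl on a saturated chain carbon bound to an aromatic carbon. Among the compounds with values here, this shortens the chain again, roughly undoing that lengthening, while bringing in a hydroxyl for which no step is measured. A rise back toward compound 1 is therefore expected, a number 24 percentage points higher from compound 2 to compound 3 (beyond the scatter), tempered for the unknown hydroxyl. The estimate for compound 3 is 75%, within 50% to 95%.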

Compound 3, a percentage reported as inhibition, at one concentration (the size of the read-out at that concentration, not a potency): 10%
Compound 3: the middle estimate sits 65 percentage points above what was measured, outside the stated range (below it).
By their numbers in this assay, from the lowest: compound 3; then compound 2; then compound 1.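

In this assay, chain length alone does not order the numbers at this saturated chain carbon bound to an aromatic carbon: 1-hydroxyethyl in place of pentyl, a shorter group, gives a number 41 percentage points lower from compound 2 to compound 3 (beyond the scatter). The same group in place of methyl gives a number 82 percentage points lower from compound 1 to compound 3 (beyond the scatter), so both steps point down, whether the group replaced is longer or shorter. Nothing measured here accounts for this loss.

From the compounds shown here alone, whether the loss follows the hydroxyl itself stays open. A plain propyl chain or a methoxy group on this carbon would separate the hydroxyl from chain length.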